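Swapping the amide substituent in a dihydropyridine series

This account rests on a few compounds, and the source may have more. Where it says the series, first, only, none or still open, it means among the compounds named here.

Three compounds that share one core differ only in the group carried on an amide-type nitrogen. Compound 1 `CCOC(=O)C1=C(C)NC(C)=C(C(=O)OCC)C1c1ccc(OCC(=O)Nc2c(C)cccc2C)cc1` is tested in a functional assay on the whole organism (strain Wistar) for inhibition, with Rattus norvegicus as the target, read by paw edema, with stated times of 30 min and 1 h, at a dose of 20 mg/kg (on this read-out higher numbers stand for more inhibition at the one dose given (going by the name of the read-out) and lower numbers for less inhibition), and gives 26.3%, the lowest of the three numbers. Compound 2 `CCOC(=O)C1=C(C)NC(C)=C(C(=O)OCC)C1c1ccc(OCC(=O)Nc2nc3ccccc3s2)cc1` gives 54.5%, and compound 3 `CCOC(=O)C1=C(C)NC(C)=C(C(=O)OCC)C1c1ccc(OCC(=O)NNC(=O)c2ccccc2)cc1` gives 29.5%. The step of a number 28.2 percentage points higher from compound 1 to compound 2 (beyond the scatter) is modest, whereas the step of a number 3.2 percentage points higher from compound 1 to compound 3 (within the scatter) lies within the scatter.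

Compound 4 `CCOC(=O)C1=C(C)NC(C)=C(C(=O)OCC)C1c1ccc(OCC(=O)NNC(=O)c2sccc2Cl)cc1`, not yet measured, changes compound 1 as follows: ((3-chlorothiophen-2-yl)carbonyl)amino in place of 2,6-dimethylphenyl on an amide-type nitrogen. The closest comparison is compound 3, whose value 29.5% shows that a benzamido group in this place left the number essentially unchanged. Compound 4 is therefore expected to sit near compound 1, with a step of a number 3.7 percentage points higher from compound 1 to compound 4 (within the scatter), and its estimated value is 30%, within 15% to 45%.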

Compound 4, a percentage reported as inhibition, in the whole organism at one dose (the size of the read-out at that dose, not a potency): 39.7%
For compound 4 the middle estimate is 9.7 percentage points below the measured one; the range from low to high includes it.
By their numbers in this assay, from the lowest: compounds 1 and 3 (each within the scatter of the next); then compound 4; then compound 2.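

Placing 3-chlorothiophen-2-yl instead of phenyl on a carbonyl carbon gives a step of a number 10.2 percentage points higher from compound 3 to compound 4 (beyond the scatter), so the ring on that carbonyl carbon matters, which compound 3 alone could not show. The ((3-chlorothiophen-2-yl)carbonyl)amino group gives a number 13.4 percentage points higher from compound 1 to compound 4 (beyond the scatter), yet still falls short of 1,3-benzothiazol-2-yl, with a number 14.8 percentage points lower from compound 2 to compound 4 (beyond the scatter). Nothing measured here explains these steps.

The chlorine and the five-membered aromatic ring enter together, and the compounds shown do not separate them. Thiophen-2-yl or 3-chlorophenyl on the same carbonyl carbon would tell them apart.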